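Replacing bromo with 3-fluorophenyl on compound 2

The compounds below may be only part of what the source reports. "The series", "measured", "known", "first", "only" and "open" are said of these compounds alone.

- Compound 1 `O=C(/C=C/c1cccc(Br)c1)c1cccc(-c2cccc(F)c2)c1`: 6550 nM
- Compound 2 `COc1ccc(/C=C/C(=O)c2cccc(Br)c2)cc1`: "not determined" (no result reported)

In a functional assay on CNE-2 cells (Homo sapiens) for cytotoxicity, read by sulforhodamine B assay, with a stated time of 48 h (a higher number here means a weaker inhibitor, a lower number a stronger inhibitor), compound 2 stands without a number, and its entry reads "not determined" (no result reported). It therefore cannot be placed above or below anything else in this small set. Compound 3 `COc1ccc(/C=C/C(=O)c2cccc(-c3cccc(F)c3)c2)cc1` has yet to be measured. The structural change that leads to it is 3-fluorophenyl in place of bromo on an aromatic carbon, which amounts to 3-fluorophenyl in place of bromo on an aromatic carbon. With no starting value, no size or direction can be expected for this step. Among the measured compounds shown here, the only guide in this assay is compound 1, which also carries a 3-fluorophenyl group and gives 6550 nM. A result in that general region is therefore expected, though with a wide margin. The expected value for compound 3 is 6000 nM, with an estimated range from 2000 nM to 18000 nM.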

Compound 3, half-maximal inhibitory concentration: 740 nM
The estimate for compound 3 lay 8.1-fold (0.91 log units) above the measured number; measured number below the stated range.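

In this assay, with the 3-fluorophenyl group held constant, 4-methoxyphenyl in place of 3-bromophenyl on the double-bonded chain carbon gives an 8.9-fold lower number from compound 1 to compound 3 (0.95 log units; beyond the scatter), so activity among these compounds depends clearly on the group at that chain position and not on the 3-fluorophenyl group alone. The step from bromo to 3-fluorophenyl itself cannot be read, since compound 2 has no number, and compound 3 therefore says nothing on its own about what that exchange contributes. No measurement is available to explain the difference between compound 1 and compound 3.

The compounds shown leave open how a dimethylamino group or a longer alkoxy chain in place of the methoxy group would behave. They also leave open whether an amine or a carboxylic acid could stand in place of the 3-fluorophenyl group.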